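This account rests on a few compounds, and the source may have more. Where it says the series, first, only, none or still open, it means among the compounds named here.

Among the compounds with values here, compound 2 `CC1CC/C(=N\Nc2ccc(-c3ccccc3)cc2)c2ncc(C(=O)O)c(=O)n21` gives 1.1 umol/kg in a functional assay on the whole organism for inhibition, with Rattus norvegicus as the target (a lower number here means that less compound is needed, a higher number that more compound is needed for the effect), and sits at the higher end of the two numbers so far, within the scatter of compound 1 `COc1ccc(N/N=C2\CCC(C)n3c2ncc(C(=O)O)c3=O)cc1`, which gives 0.8 umol/kg. Within the data shown here, the only measured step, a 1.4-fold higher number from compound 1 to compound 2 (0.14 log units; within the scatter), stays within the scatter. Compound 3 `CC1CC/C(=N\Nc2ccc(CC(=O)O)cc2)c2ncc(C(=O)O)c(=O)n21` is not yet measured; (carboxymethyl in place of phenyl on an aromatic carbon). Among the measured compounds shown here, no measured step covers carboxymethyl entering at this position, so the change from compound 2 to compound 3 has no direct precedent. For compound 3 a modest rise within a wide range is expected, a 1.8-fold higher number from compound 2 to compound 3 (0.26 log units; within the scatter). Compound 3 is thus expected to give 2 umol/kg in this assay, between 0.6 umol/kg and 7 umol/kg.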

Compound 3, dose for 50% inhibition: 60.9 umol/kg
The estimate for compound 3 lay 30-fold (1.48 log units) below the measured number; measured number above the stated range.
By their numbers in this assay, from the lowest: compounds 1 and 2 (each within the scatter of the next); then compound 3.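

At this place on the aromatic ring, para to a large group, the substituent does matter. In this assay, carboxymethyl brings a 55-fold higher number from compound 2 to compound 3 (1.74 log units; beyond the scatter) and a 76-fold higher number from compound 1 to compound 3 (1.88 log units; beyond the scatter), whereas methoxy and phenyl stayed within the scatter of each other. Nothing measured here bears on the reason for this rise. The compounds shown leave open whether the rise goes with the carboxylic acid of the carboxymethyl group or with the departure of the phenyl ring. A methyl ester of that chain, an amine or a plain ethyl group here would help separate these two readings.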